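Maximal response in YAC-1 cells: benzyl versus methyl on the core

The compounds below may be only part of what the source reports. "The series", "measured", "known", "first", "only" and "open" are said of these compounds alone.

Measured compounds:
compound 1, `Nc1nc(O)c2c(n1)n(C1OC(CO)[C@@H](O)[C@H]1O)c(=O)n2Cc1ccc(Cl)c(Cl)c1`, 15%
compound 2, `Nc1nc(O)c2c(n1)n(C1OC(CO)[C@@H](O)[C@H]1O)c(=O)n2Cc1ccc(Cl)cc1`, 27%
compound 3, `Cn1c(=O)n(C2OC(CO)[C@@H](O)[C@H]2O)c2nc(N)nc(O)c21`, 72%

Within a functional assay on YAC-1 cells (Mus musculus) (a higher number here means a larger maximal response, a lower number a smaller maximal response), compound 3 stands highest of the three; the nearest is compound 2 at 27%, and compound 1 at 15% lies furthest off, both gaps beyond the scatter. Among the measured compounds, a number 12 percentage points higher from compound 1 to compound 2 (beyond the scatter), a modest shift from one chlorinated benzyl to the other. The substitution that removes the benzyl-type group altogether is what matters: a number 57 percentage points higher from compound 1 to compound 3 (beyond the scatter) and a number 45 percentage points higher from compound 2 to compound 3 (beyond the scatter), both large.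

Compound 4, `Nc1nc(O)c2c(n1)n(C1OC(CO)[C@@H](O)[C@H]1O)c(=O)n2Cc1ccc([N+](=O)[O-])cc1`, is the next step from compound 3: 4-nitrophenyl in place of hydrogen on a saturated chain carbon bound to an aromatic nitrogen. Cut one bond further out the change reads methyl to 4-nitrobenzyl, which places it in the same family as the two large steps already seen, run backwards. Both steps bear directly on it, since each introduced a hydrogen where a substituted benzyl carbon had stood and each gained a large amount in this assay; going the other way, a large loss is expected. Among the compounds with values here, the nitro-substituted ring has no direct precedent here, so the exact size is uncertain, but on the strength of a number 57 percentage points higher from compound 1 to compound 3 (beyond the scatter) and a number 45 percentage points higher from compound 2 to compound 3 (beyond the scatter) compound 4 is expected at 25%, within 10% to 45%, which means an expected step of a number 47 percentage points lower from compound 3 to compound 4 (beyond the scatter).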

Compound 4, largest response reached (reported as maximal response), in percent of the reference or control that the assay uses: 50%
For compound 4 the middle estimate is 25 percentage points below the measured one, outside the stated range (above it).
By their numbers in this assay, from the lowest: compound 1; then compound 2; then compound 4; then compound 3.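

In this assay, adding a substituted benzyl-type group to compound 3 does not have to cost as much as the chlorinated examples suggested: 4-nitrophenyl in place of hydrogen on a saturated chain carbon bound to an aromatic nitrogen gives a number 22 percentage points lower from compound 3 to compound 4 (beyond the scatter) and that step is only modest. What the ring carries therefore counts at this position alongside the presence of the ring itself, as nitro in place of chloro on an aromatic carbon gives a number 23 percentage points higher from compound 2 to compound 4 (beyond the scatter) and 4-nitrophenyl in place of 3,4-dichlorophenyl gives a number 35 percentage points higher from compound 1 to compound 4 (beyond the scatter) in the same assay. Among the three compounds with a benzyl-type group, compound 4 stands highest, yet the methyl of compound 3 remains ahead of all of them.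

No measurement beyond the maximal response accompanies these compounds, and the reason for the gain with nitro remains unexplained. As far as these compounds go, it remains open whether an amine or a carboxylic acid on the ring, or a longer chain carrying the ring, would lie nearer compound 3 or nearer compound 1.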